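From 2-chlorophenyl to 4-chlorophenyl: an expected gain

This account rests on a few compounds, and the source may have more. Where it says the series, first, only, none or still open, it means among the compounds named here.

In a functional assay on SGC-7901 cells (Homo sapiens) for antiproliferative activity, read by MTT assay, with a stated time of 48 h (a higher number here means a weaker inhibitor, a lower number a stronger inhibitor), compound 1 `Fc1ccc(-c2nnc(SCc3ccc(Cl)nc3)o2)cc1` gives 3.67 ug/mL and compound 2 `Clc1ccc(CSc2nnc(-c3ccccc3Cl)o2)cn1` gives 13.5 ug/mL, so compound 2 holds the higher of the two numbers and is the weaker inhibitor. Compound 3 `Clc1ccc(-c2nnc(SCc3ccc(Cl)nc3)o2)cc1` differs from compound 2 as follows: 4-chlorophenyl in place of 2-chlorophenyl on an aromatic carbon. It carries 4-chlorophenyl in place of 2-chlorophenyl on an aromatic carbon. Within the data shown here, only one measured step bears on this change: a 3.7-fold higher number from compound 1 to compound 2 (0.57 log units; beyond the scatter), a modest step that brought in 2-chlorophenyl in place of 4-fluorophenyl. Among the measured compounds shown here, no measured pair isolates the change from 2-chlorophenyl to 4-chlorophenyl. Still, the 4-chlorophenyl of compound 3 resembles the 4-fluorophenyl of compound 1, which gives 3.67 ug/mL, so a modest move toward a lower number is expected. The expected change is a 2.7-fold lower number from compound 2 to compound 3 (0.43 log units; beyond the scatter). For compound 3 the estimated value is 5 ug/mL, with an expected range of 2 ug/mL to 12 ug/mL.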

Compound 3, half-maximal inhibitory concentration: 8.62 ug/mL
For compound 3 the middle estimate is 1.7-fold (0.24 log units) below the measured one; the range from low to high includes it.
By their numbers in this assay, from the lowest: compound 1; then compounds 3 and 2 (each within the scatter of the next).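

In this assay, among these compounds, this is the first pair to isolate 2-chlorophenyl against 4-chlorophenyl, and it gives a 1.6-fold lower number from compound 2 to compound 3 (0.19 log units; within the scatter), so this change on this aromatic carbon is not resolved from the scatter. The halogen does register: with chloro in place of fluoro there is a 2.3-fold higher number from compound 1 to compound 3 (0.37 log units; beyond the scatter), which sets the 4-fluorophenyl of compound 1 apart from the 4-chlorophenyl of compound 3 by a modest step. The data offer no independent measurement that accounts for either result.

The compounds shown leave open whether a methoxy group or an amine in place of the halogen on the phenyl ring would keep or lose activity. On these data alone, the other side of the shared core is the same in all three compounds, so the effect of any change there remains unknown.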